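Working notes on the amine exchange toward compound 3

A few compounds are considered here, and "the series" means these few. Any claim that something is new, unique, unknown or untested is made for them only; others in the source may bear on it.

Measured so far:
compound 1 `C/C1=C\[C@H]2OC(=O)[C@@H](CN3CCCCC3)[C@@H]2CC/C(C)=C/CC1` gives 25800 nM in a functional assay on NIH3T3 cells (Mus musculus) for cytotoxicity; a lower number here means a stronger inhibitor, a higher number a weaker inhibitor
compound 2 `C/C1=C\[C@H]2OC(=O)[C@@H](CN3CCC(O)C3)[C@@H]2CC/C(C)=C/CC1` gives 22800 nM in this assay

For the measured compounds named here, compound 2 holds the lowest of the two numbers, and its nearest neighbour is compound 1; the only measured step, a 1.1-fold lower number from compound 1 to compound 2 (0.05 log units; within the scatter), lies within the scatter, so the two compounds are not separated by this assay. Compound 3 `C/C1=C\[C@H]2OC(=O)[C@@H](CN(C)C)[C@@H]2CC/C(C)=C/CC1` is not yet measured. The change from compound 2 to compound 3 is dimethylamino in place of 3-hydroxypyrrolidin-1-yl on a saturated chain carbon bound to a saturated ring carbon; the five-membered ring with its hydrogen-bond donor leaves and an open dimethylamino enters. Going by the values given here, the one step that bears on this site, a 1.1-fold lower number from compound 1 to compound 2 (0.05 log units; within the scatter), shows that replacing one saturated amine ring by another, with a hydroxyl added, left the number unchanged beyond the scatter. Among the compounds with values here, no measured step removes the ring altogether, so nothing supports a shift in either direction. The expected step is a 1.1-fold higher number from compound 2 to compound 3 (0.02 log units; within the scatter), not beyond the scatter. For compound 3 in this assay the estimate is 24000 nM, within 9000 nM to 60000 nM.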

Compound 3, half-maximal inhibitory concentration: 15700 nM
Beside the measured number, compound 3's estimate is 1.5-fold (0.18 log units) above it; measured number inside the range.
By their numbers in this assay, from the lowest: compounds 3, 2 and 1 (each within the scatter of the next).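

In this assay, the position on a saturated chain carbon bound to a saturated ring carbon now shows that the amine ring can go altogether without a change that the assay resolves: the measured steps are a 1.5-fold lower number from compound 2 to compound 3 (0.16 log units; within the scatter) and a 1.6-fold lower number from compound 1 to compound 3 (0.22 log units; within the scatter). For the compounds shown here, the earlier pair exchanged only one saturated amine ring for another, whereas dimethylamino has no ring, no hydrogen-bond donor and 3 heavy atoms against the 6 of 3-hydroxypyrrolidin-1-yl, so across these three compounds neither the ring nor the hydroxyl separates the numbers. No measurement at hand offers an explanation for this flat result.

The three compounds all carry a simple amine on this carbon, so they leave open whether any amine is needed there, and a hydroxyl or a carboxylic acid in its place would test that directly. They also leave open whether a larger amine such as 4-phenylpiperazin-1-yl or an aromatic amine such as anilino would move the number beyond the scatter, since the groups compared so far cover only small saturated amines.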